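From Chloro to Methoxy: Estimating Compound 4

The compounds below may be only part of what the source reports. "The series", "measured", "known", "first", "only" and "open" are said of these compounds alone.

Three measured compounds share one core and differ only in the small groups on the six-membered aromatic ring of carbon only that carries the carbonyl. Compound 1 `O=C(Nc1nnc(-c2ccc(Cl)cc2)s1)c1c(Cl)cccc1Cl` bears two chloro groups there; in a functional assay on the whole organism (integument) for inhibition, with Chilo suppressalis as the target, read by scintillation counting, with a stated time of 72 h (a lower number here means a stronger inhibitor, a higher number a weaker inhibitor), compound 1 gives 380 nM. Compound 2 `Cc1cccc(C)c1C(=O)Nc1nnc(-c2ccc(Cl)cc2)s1` carries two methyl groups instead, and in this assay compound 2 gives 69.2 nM. Compound 3 `O=C(Nc1nnc(-c2ccc(Cl)cc2)s1)c1ccccc1Cl` keeps only a single chloro. For compound 3 this assay reports only a limit, > 5010 nM, so its true number is not known; it sits at the limit of > 5010 nM in this assay, at which 1 of the 3 values shown sits. Going by the values given here, the one measured step that reaches compound 3 is an at least 13-fold higher number from compound 1 to compound 3 (1.12 log units; beyond the scatter): taking away one chloro costs a great deal.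

Compound 4 `COc1ccccc1C(=O)Nc1nnc(-c2ccc(Cl)cc2)s1` is made from compound 3 by methoxy in place of chloro on an aromatic carbon. Among the compounds with values here, no measured pair contains a methoxy, so nothing bears directly on this change; the step from compound 1 to compound 3 shows only that this part of the molecule matters, and compound 2 shows that methyl groups there can give a low number. Since compound 3 stands at a limit, the expected step of an at least 2.0-fold lower number from compound 3 to compound 4 (0.30 log units; that floor lies within the scatter) is uncertain in size and could fall either way. Compound 4 is expected to land near 2500 nM, somewhere between 400 nM and 12000 nM.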

Compound 4, half-maximal inhibitory concentration: 53.7 nM
Compound 4: the middle estimate sits 47-fold (1.67 log units) above what was measured; measured number below the stated range.
By their numbers in this assay, from the lowest: compounds 4 and 2 (each within the scatter of the next); then compound 1. At a limit, above all of these: compound 3.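

With a single group on this ring in both compounds, methoxy in place of chloro gives an at least 93-fold lower number from compound 3 to compound 4 (1.96 log units; beyond the scatter) in this assay. Going by these compounds alone, the earlier compounds showed only that taking one chloro away from compound 1 is costly, which left open whether a ring with one group could give a low number at all; this step shows that it can, and that the identity of the single group at this place decides a great deal. The step is only a floor, and its true size is unknown, since the number for compound 3 is a limit: the limit of > 5010 nM in this assay, at which 1 of the 4 values shown sits.

The compounds shown do not tell which feature of methoxy makes the difference, whether its extra heavy atom or the hydrogen-bond acceptor counted on it, and nothing here ties the change to either. Going by these compounds, how far the effect extends also remains open: a single methyl, a hydroxy group, an ethoxy group or an amine at the same place could each help to separate these possibilities, as could a second methoxy on the ring.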